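The source may hold more compounds than are shown below. What is called first, only, known or untested is meant among the compounds shown, and "the series" means these compounds.

Compound 2 `C#CCOc1cc(/C=C/C(=O)c2ccc(OC)c3c2OC(C)(C)C=C3)ccc1OC` gives > 10000 nM in a functional assay on HepG2 cells (Homo sapiens) for cytotoxicity, read by MTT assay (on this read-out higher numbers stand for weaker inhibition and lower numbers for stronger inhibition), which is a limit of the assay and not a number, (the limit of > 10000 nM in this assay, at which 1 of the 3 values shown sits). Compound 1 `COc1ccc(/C=C/C(=O)c2ccc(OC)c3c2OC(C)(C)C=C3)cc1O` gives 450 nM in this assay, and compound 3 `COc1ccc(/C=C/C(=O)c2ccc(OC)c3c2OC(C)(C)C=C3)cc1OC(=O)CCl` gives 120 nM. The measured steps run an at least 22-fold higher number from compound 1 to compound 2 (1.34 log units; beyond the scatter), a 3.8-fold lower number from compound 1 to compound 3 (0.57 log units; beyond the scatter) and an at least 83-fold lower number from compound 2 to compound 3 (1.92 log units; beyond the scatter). Compound 4 `COc1ccc(/C=C/C(=O)c2ccc(OC)c3c2OC(C)(C)C=C3)cc1OC(=O)C1CC1` differs from compound 2 by cyclopropylcarbonyl in place of propargyl on an oxygen on an aromatic ring. The step bearing most directly on it is an at least 83-fold lower number from compound 2 to compound 3 (1.92 log units; beyond the scatter), which also exchanges propargyl for an acyl group on the same oxygen, while a 3.8-fold lower number from compound 1 to compound 3 (0.57 log units; beyond the scatter) shows an acyl ester on that oxygen is tolerated. A large drop from compound 2 to compound 4 in this assay is therefore expected, an at least 33-fold lower number from compound 2 to compound 4 (1.52 log units; beyond the scatter). Compound 4 is estimated at 300 nM, with a range from 100 nM to 1500 nM.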

Compound 4, half-maximal inhibitory concentration: 220 nM
Compound 4: middle estimate off by 1.4-fold (0.13 log units), on the high side, within the range that was stated.
By their numbers in this assay, from the lowest: compounds 3 and 4 (each within the scatter of the next); then compound 1. At a limit, above all of these: compound 2.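

Cyclopropylcarbonyl on this oxygen repeats what (chloromethyl)carbonyl did against propargyl, with an at least 45-fold lower number from compound 2 to compound 4 (1.65 log units; beyond the scatter) in this assay. Compound 2 stands at a limit and not a number, which makes that step a bound only: the limit of > 10000 nM in this assay, at which 1 of the 4 values shown sits. The low number does not require chloromethyl, as a 1.8-fold higher number from compound 3 to compound 4 (0.26 log units; within the scatter), and the ester still differs from the hydrogen on that oxygen, with a 2.0-fold lower number from compound 1 to compound 4 (0.31 log units; beyond the scatter).

As far as these compounds go, whether a longer acyl chain or a benzoyl group on this oxygen keeps the number of the two esters stays open. From the compounds shown here alone, it is equally open whether a carbamate or a plain ethyl ether follows the esters or propargyl.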